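The compounds below may be only part of what the source reports. "The series", "measured", "known", "first", "only" and "open" are said of these compounds alone.

Two compounds share one core and differ only in what sits on the six-membered aromatic ring of carbon only. In a functional assay on BGC-823 cells (Homo sapiens) for cytotoxicity, read by CCK-8 assay, with a stated time of 24 h (on this read-out higher numbers stand for weaker inhibition and lower numbers for stronger inhibition), compound 1 `C/C(=C\c1cc(-c2ccccc2)cs1)C(N)=O` gives > 50000 nM, which is a limit of the assay rather than a number. Compound 2 `C/C(=C\c1cc(-c2ccc(C#N)cc2)cs1)C(N)=O`, which adds a cyano group to the shared core, gives in this assay > 50000 nM, again only a limit. The step that the two limits leave unreadable from compound 1 to compound 2 therefore cannot be read, because of the limit of > 50000 nM in this assay, at which 2 of the 2 values shown sit. Going by the values given here, compound 2 thus stands only as a limit in this assay, and the one other value shown is a limit as well. Compound 3 `C/C(=C\c1cc(-c2ccc([N+](=O)[O-])cc2)cs1)C(N)=O` has not yet been measured; it differs from compound 2 by nitro in place of cyano on an aromatic carbon. Among the compounds with values here, the only measured step, the exchange of hydrogen for cyano, was itself unreadable, so no measured step bears on the exchange of cyano for nitro. The expectation for compound 3 in this assay is therefore that it most likely reaches only the same limit, an estimated step that the limit leaves unreadable from compound 2 to compound 3. Compound 3 is estimated at 60000 nM, within a range from 20000 nM to 200000 nM.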

Compound 3, half-maximal inhibitory concentration: > 50000 nM
Compound 3: a limit, no number (the forecaster's own chance of this, stated with the estimate: 85%); the middle value does not contradict the limit.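

Compound 3 also ends at a limit of the assay rather than a number, so the steps to it from compound 1 and from compound 2 cannot be read: the limit of > 50000 nM in this assay, at which 3 of the 3 values shown sit. The compounds shown leave open how hydrogen, cyano and nitro on the six-membered aromatic ring compare in this assay, since none of compound 1, compound 2 or compound 3 has a number there.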